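This account rests on a few compounds, and the source may have more. Where it says the series, first, only, none or still open, it means among the compounds named here.

The measured compounds:
compound 1, `COc1ccccc1-c1cnc(C(=O)CCCCCCc2ccccc2)o1`: 400 nM
compound 2, `Cc1cccnc1-c1cnc(C(=O)CCCCCCc2ccccc2)o1`: 15 nM
compound 3, `O=C(CCCCCCc1ccccc1)c1ncc(-c2ncccc2C(=O)O)o1`: > 50 nM

In an assay (Rattus norvegicus) for inhibition of Fatty-acid amide hydrolase 1 (Homo sapiens) (a higher number here means a weaker inhibitor, a lower number a stronger inhibitor), compound 1 gives 400 nM, the highest of the two numbers shown; its nearest neighbour is compound 2, reached by a 27-fold lower number from compound 1 to compound 2 (1.43 log units; beyond the scatter). The value of compound 3 in this assay, > 50 nM, is a limit of the assay and not a number (the limit of > 50 nM in this assay, at which 1 of the 3 values shown sits). Between compound 2 and compound 3 stands an at least 3.3-fold higher number from compound 2 to compound 3 (0.52 log units; beyond the scatter).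

Compound 4, `O=C(CCCCCCc1ccccc1)c1ncc(-c2ncccn2)o1`, has not yet been measured in this assay. It differs from compound 1 in one place: pyrimidin-2-yl in place of 2-methoxyphenyl on an aromatic carbon. The step that bears most closely on it is the exchange of 2-methoxyphenyl for 3-methylpyridin-2-yl, a 27-fold lower number from compound 1 to compound 2 (1.43 log units; beyond the scatter), a large one. The step to 3-carboxypyridin-2-yl, a step that the limit leaves unreadable from compound 1 to compound 3, is left unreadable by the limit (the limit of > 50 nM in this assay, at which 1 of the 3 values shown sits). As pyrimidin-2-yl shares the ring nitrogen of compound 2 but lacks its methyl, the drop for compound 4 is expected to be large yet smaller than that seen for compound 2, giving an expected 6.7-fold lower number from compound 1 to compound 4 (0.82 log units; beyond the scatter). Compound 4 is therefore estimated at 60 nM, between 15 nM and 250 nM.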

Compound 4, inhibition constant: 5.3 nM
For compound 4 the middle estimate is 11-fold (1.05 log units) above the measured one, and the stated range ends above it.
By their numbers in this assay, from the lowest: compound 4; then compound 2; then compound 1.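

In this assay, the exchange on this aromatic carbon next to the ring oxygen reaches further than compound 2 had shown, with a 75-fold lower number from compound 1 to compound 4 (1.88 log units; beyond the scatter), and a low number turns out not to need a substituent on the incoming ring, with a 2.8-fold lower number from compound 2 to compound 4 (0.45 log units; beyond the scatter). The ring bearing the carboxy group stands well apart from the pyrimidin-2-yl ring, with an at least 9.4-fold lower number from compound 3 to compound 4 (0.97 log units; beyond the scatter). The value of compound 3 is a limit and not a number: the limit of > 50 nM in this assay, at which 1 of the 4 values shown sits.

The step between compound 2 and compound 4 changes the ring nitrogens and the methyl together, and the compounds shown do not separate the two; an unsubstituted pyridin-2-yl group would speak to this. As far as these compounds go, how an amine or a methyl ester on the pyrimidin-2-yl ring would read also remains open.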